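The compounds below may be only part of what the source reports. "The series", "measured", "known", "first", "only" and "open" are said of these compounds alone.

Measured compounds:
Compound 1, `COc1ccc(-c2cc(/C=C/C(=O)c3ccc(N)cc3)[nH]n2)cc1`: 80%
Compound 2, `COc1cc(-c2cc(/C=C/C(=O)c3ccc(Cl)c(Cl)c3)[nH]n2)cc(OC)c1OC`: 97%

In a functional assay on MOLT-4 cells (Homo sapiens) for cytotoxicity, read by sulforhodamine B assay, with a stated time of 48 h, tested at 1 uM (a lower number here means a stronger effect, a higher number a weaker effect of the compound at the concentration tested), compound 1 gives 80%, the lowest of the two numbers; compound 2 gives 97%, a number higher by more than the scatter. Compound 3, `COc1ccc(-c2cc(/C=C/C(=O)c3ccc(N)cc3)[nH]n2)cc1OC`, has not been measured. It differs from compound 1 in a single place, (methoxy in place of hydrogen on an aromatic carbon). Within the data shown here, no pair of measured compounds shows this change on its own, so the size of the step is open; the account expects at most a small step from compound 1 to compound 3, if any, and leaning towards a weaker effect, an expected a number 5 percentage points higher from compound 1 to compound 3 (within the scatter). The estimate for compound 3 is 85%, expected within 68% to 100%.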

Compound 3, a percentage reported as activity, at one concentration (the size of the read-out at that concentration, not a potency): 93%
Beside the measured number, compound 3's estimate is 8 percentage points below it; low and high end bracket the measured number.
By their numbers in this assay, from the lowest: compound 1; then compounds 3 and 2 (each within the scatter of the next).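

In this assay, the step of a number 13 percentage points higher from compound 1 to compound 3 (beyond the scatter) shows that methoxy in place of hydrogen on an aromatic carbon, ortho to a methoxy group and meta to a large group, is not a silent change, and that it goes towards a weaker effect at the concentration tested. It is the only single-place step among the compounds shown. No measurement shown here offers an explanation for it.

As far as these compounds go, whether fluorine or a hydroxyl group in the same place would give a smaller step remains open. So does whether methoxy acts alike on other compounds.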